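Compound 2 to Compound 4: Methylsulfonyl Replaces the Nitrile Chain

The compounds below may be only part of what the source reports. "The series", "measured", "known", "first", "only" and "open" are said of these compounds alone.

Three compounds have been measured in a functional assay on the whole organism (stomach) for inhibition, with Canis familiaris (Canis lupus familiaris) as the target, at a dose of 5 mg/kg by the intravenous route; on this read-out lower numbers stand for a weaker effect and higher numbers for a stronger effect at the one dose given:
compound 1 `CC(=O)c1c(C)nc2c(OCc3ccccc3)cccn12` gives 9%;
compound 2 `Cc1nc2c(OCc3ccccc3)cccn2c1CCC#N` gives 20%;
compound 3 `CCSCc1c(C)nc2c(OCc3ccccc3)cccn12` gives 0%.

Compound 2 stands highest of the three numbers, with a number 11 percentage points higher from compound 1 to compound 2 (beyond the scatter) and a number 20 percentage points lower from compound 2 to compound 3 (beyond the scatter) both beyond the scatter, while a number 9 percentage points lower from compound 1 to compound 3 (within the scatter) is within it.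

Compound 4 `Cc1nc2c(OCc3ccccc3)cccn2c1CS(C)(=O)=O` differs from compound 2 in one place: methylsulfonyl in place of cyanomethyl on a saturated chain carbon bound to an aromatic carbon. For the measured compounds named here, the step that bears most on this change is the one from compound 2 to compound 3, which also replaced cyanomethyl at that same saturated chain carbon, with a number 20 percentage points lower from compound 2 to compound 3 (beyond the scatter). The step to compound 1, a number 11 percentage points higher from compound 1 to compound 2 (beyond the scatter), shows that the cyanoethyl chain carries the highest number seen so far. Only one replacement at that position has been measured, and it lowered the number, so for compound 4 a modest drop is expected, a number 10 percentage points lower from compound 2 to compound 4 (within the scatter), with a real chance of no change beyond the scatter. Compound 4 is therefore estimated at 10%, between 0% and 25%.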

Compound 4, a percentage reported as inhibition, in the whole organism at one dose (the size of the read-out at that dose, not a potency): 0%
For compound 4 the middle estimate is 10 percentage points above the measured one; measured number inside the range.
By their numbers in this assay, from the lowest: compounds 3, 4 and 1 (each within the scatter of the next); then compound 2.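

In this assay a second replacement at the saturated chain carbon bound to an aromatic carbon also falls short of the 2-cyanoethyl chain, with a number 20 percentage points lower from compound 2 to compound 4 (beyond the scatter) as the step, so neither replacement measured there matches that chain. Methylsulfonyl and ethylsulfanyl at that carbon cannot be told apart, with no change at the digits printed from compound 3 to compound 4 (within the scatter) between them, and the (methylsulfonyl)methyl group cannot be told from acetyl on the aromatic carbon, with a number 9 percentage points lower from compound 1 to compound 4 (within the scatter) as that step. No measurement shown here accounts for these numbers.

As far as these compounds go, whether the higher number depends on the nitrile itself or on the length of the chain remains open, and a longer chain ending in a nitrile, an amine or a carboxylic acid at that carbon would bear on this. All these numbers also come from a single dose, which leaves open how the compounds compare at other doses.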